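This account rests on a few compounds, and the source may have more. Where it says the series, first, only, none or still open, it means among the compounds named here.

Measured so far in a functional assay on NUGC-3 cells (Homo sapiens) for inhibition, read by sulforhodamine B assay, with a stated time of 48 h; on this read-out lower numbers stand for stronger inhibition of growth and higher numbers for weaker inhibition of growth:

Compound 1, `O=C(Nc1ccc(C(F)(F)F)cc1)C1c2ccccc2CCN1C(=O)c1ccc(Cl)cc1` — compound 1 gives 4200 nM.
Compound 3, `O=C(Nc1ccc(C(F)(F)F)cc1)C1NCCc2ccccc21` — compound 3 gives 4220 nM.
Compound 2, `O=C(Nc1ccccc1Cl)c1nccc2ccccc12` — for compound 2 the result is a limit of this assay, > 10000 nM.

Compound 1 stands lowest of the two numbers shown, with compound 3 nearest and within the scatter of it. Compound 2 sits at the limit of > 10000 nM in this assay, at which 1 of the 3 values shown sits. Going by the values given here, the one measured step, a 1.0-fold higher number from compound 1 to compound 3 (0.00 log units; within the scatter), concerns the ring nitrogen and not the anilide part.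

Compound 4, `O=C(Nc1ccc(O)cc1)C1c2ccccc2CCN1C(=O)c1ccc(Cl)cc1`, differs from compound 1 by hydroxy in place of trifluoromethyl on an aromatic carbon. Among the compounds with values here, no measured step touches this place; the only step available, the one from compound 1 to compound 3, lies elsewhere and was within the scatter, so it gives no direction for the change in the anilide ring. For compound 4 the expectation is therefore set near the value of compound 1, with a wide range to cover either direction. For compound 4 the estimated value is 5000 nM, between 1500 nM and 15000 nM. The expected step of a 1.2-fold higher number from compound 1 to compound 4 (0.08 log units; within the scatter) is small, without a direction claimed beyond the scatter.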

Compound 4, concentration for 50% growth inhibition: > 10000 nM
Compound 4: no number, only a limit (the forecaster's own chance of this, stated with the estimate: 25%); middle value at least 2.0-fold (0.30 log units) away from the limit.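

In this assay the ring nitrogen and the anilide ring now read differently. Going by these compounds alone, the step at the ring nitrogen, a 1.0-fold higher number from compound 1 to compound 3 (0.00 log units; within the scatter), gave no separation, whereas hydroxy in place of trifluoromethyl on the aromatic carbon gives an at least 2.3-fold higher number from compound 1 to compound 4 (0.37 log units; beyond the scatter), so this position is the first where a single change is seen to matter. For compound 4 the result is a limit of the assay, > 10000 nM, so the step has a lower bound and its full size cannot be read: the limit of > 10000 nM in this assay, at which 2 of the 4 values shown sit.

As far as these compounds go, it remains open whether the step follows from the loss of trifluoromethyl or the arrival of hydroxy, which a methoxy group, a chlorine or an amine at the same carbon would help separate. From the compounds shown here alone, it is also open whether the same change reads alike on the core of compound 3, with its free ring nitrogen.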